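A few compounds are considered here, and "the series" means these few. Any claim that something is new, unique, unknown or untested is made for them only; others in the source may bear on it.

Measured compounds in this series:
compound 1 `C[C@H](COP(=O)(O)OC[C@H](N)C(=O)O)OC(=O)CCc1ccccc1OCc1cccc(Oc2ccccc2)c1` with 13.8%
compound 2 `CCCCCCCCCCCOc1ccccc1CCC(=O)O[C@@H]1COCC[C@@H]1OP(=O)(O)OC[C@H](N)C(=O)O` with 12%

In an assay on HEK293 cells for agonist activity at putative P2Y purinoceptor 10 (Mus musculus), with a stated time of 1 h (a higher number here means a larger maximal response, a lower number a smaller maximal response), compound 1 gives 13.8%. In this assay compound 2 gives 12%. The two numbers lie within the usual scatter of each other, so compound 2 and compound 1 cannot be told apart on this measure; both sit at a small maximal response against the reference.

The step under consideration runs from compound 2 to compound 3 `CCCCCCCCCCCOc1ccccc1CCC(=O)O[C@H]1COCC[C@@H]1OP(=O)(O)OC[C@H](N)C(=O)O`. The change is the two compounds have the same atoms and bonds; at least one stereo element is drawn with a configuration in one of them and without one in the other: 1 of 4 stereo elements differ; a stereocentre at a saturated ring carbon is drawn R in compound 2 and S in compound 3. For the measured compounds named here, no measured pair shows a step of this kind, and no pair differing in only one place has been measured at all, so nothing is known here about how the configuration at that ring carbon affects the maximal response.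

With both measured values close together and small, the expectation for compound 3 rests on compound 2 alone, whose value 12% is the only anchor. A step beyond the scatter is not expected in either direction; the estimated step of no change at the digits printed from compound 2 to compound 3 (within the scatter) is taken as essentially none. Compound 3 is expected to give about 12%, within 4% to 24%.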

Compound 3, largest response reached (Emax), in percent of the reference or control that the assay uses: 12.4%
Estimate against measurement, compound 3: 0.4 percentage points below; the measured number falls inside the stated range.
By their numbers in this assay, from the lowest: compounds 2, 3 and 1 (each within the scatter of the next).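

Inverting the stereocentre at the saturated ring carbon, drawn R in compound 2 and S in compound 3, gives the first reading of a change in one place in this series: in this assay there is a number 0.4 percentage points higher from compound 2 to compound 3 (within the scatter). On this read-out, the configuration at that ring carbon therefore does not separate the two compounds, and the pair stays at a small maximal response with either drawing. One qualification applies to how the pair is read, and it concerns the drawing rather than the response: the fact that one of compounds 2 and 3 is drawn with a defined configuration and the other without, at the place where they differ.

Still open, from the compounds shown here alone, is whether the other stereo elements of the shared core behave in the same way, or whether the flat result holds only for this ring carbon and this long ether chain. Also open, going by these compounds, is whether a change to the linkage or the chain, such as an amide in place of the ester or a shorter alkyl chain on the ether oxygen, would move the maximal response beyond the scatter.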